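Swapping a Furan Ring for a Propylsulfanyl Chain

The source may report more compounds than this note shows. Statements on the series, on what has been measured and on what is new or still open speak of the compounds shown alone.

compound 1, `Cc1cc(C)c(S(C)(=O)=O)cc1C(=O)N=C(N)N`, gives 11 nM in a functional assay for inhibition of sodium/hydrogen exchanger (Oryctolagus cuniculus); on this read-out lower numbers stand for stronger inhibition and higher numbers for weaker inhibition
compound 2, `Cc1cc(-c2ccccc2)c(S(C)(=O)=O)cc1C(=O)N=C(N)N`, gives 19 nM in this assay
compound 3, `Cc1cc(-c2ccco2)c(S(C)(=O)=O)cc1C(=O)N=C(N)N`, gives 16 nM in this assay

Three compounds share one core and differ only in one group on an aromatic carbon. In this assay compound 3 stands second highest of the three numbers; the nearest neighbour is compound 2, the furthest compound 1, and both gaps are within the scatter: a 1.2-fold lower number from compound 2 to compound 3 (0.07 log units; within the scatter) and a 1.5-fold higher number from compound 1 to compound 3 (0.16 log units; within the scatter).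

Compound 4, `CCCSc1cc(C)c(C(=O)N=C(N)N)cc1S(C)(=O)=O`, has not yet been measured. It differs from compound 3 in one place: propylsulfanyl in place of furan-2-yl on an aromatic carbon.

All three measured steps bear on this change, since each replaces the group at this same aromatic carbon: a 1.7-fold higher number from compound 1 to compound 2 (0.24 log units; within the scatter), a 1.5-fold higher number from compound 1 to compound 3 (0.16 log units; within the scatter) and a 1.2-fold lower number from compound 2 to compound 3 (0.07 log units; within the scatter). Each of them lies within the scatter, so the group at this position has so far made no difference that can be told apart from repeat measurements. For the measured compounds named here, none of the measured steps, though, brings in a chain without a ring, so that part of the change is untested.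

The expectation is therefore a step of no more than the scatter in this assay, in no particular direction. Compound 4 is estimated at 15 nM, with a range from 5 nM to 45 nM. That estimate means an expected step of a 1.1-fold lower number from compound 3 to compound 4 (0.03 log units; within the scatter).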

Compound 4, half-maximal inhibitory concentration: 6.8 nM
Compound 4: middle estimate off by 2.2-fold (0.34 log units), on the high side, within the range that was stated.
By their numbers in this assay, from the lowest: compounds 4, 1, 3 and 2 (each within the scatter of the next, the first and the last beyond it).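

In this assay, for the compounds shown here, the group on this aromatic carbon had so far given no step that could be told apart from repeat measurements, but propylsulfanyl, a chain with no ring, now gives modest steps against both ring groups: a 2.4-fold lower number from compound 3 to compound 4 (0.37 log units; beyond the scatter) and a 2.8-fold lower number from compound 2 to compound 4 (0.45 log units; beyond the scatter). Against the methyl group there is no such separation, with a 1.6-fold lower number from compound 1 to compound 4 (0.21 log units; within the scatter), so the chain can be told apart from furan-2-yl and phenyl but not from methyl, and the position accepts this ringless group with no loss relative to the methyl compound. Nothing available explains why the chain separates from the two rings, and no measurement beyond these numbers bears on the result.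

With only one chain among these compounds, it remains open whether its length or its sulfur atom matters, which a shorter ethylsulfanyl, a longer butylsulfanyl, or a propoxy group with oxygen in place of sulfur could help to separate. On these data alone, it is also open whether a chain with no sulfur at all, such as plain butyl, or an amine on this carbon would behave like propylsulfanyl or like the rings.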